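Fluoro to chloro on compound 2

A few compounds are considered here, and "the series" means these few. Any claim that something is new, unique, unknown or untested is made for them only; others in the source may bear on it.

In a functional assay on HL-60 cells (Homo sapiens) for cytotoxicity, read by XTT assay, with a stated time of 3 days (on this read-out lower numbers stand for stronger inhibition and higher numbers for weaker inhibition), compound 1 (`OC[C@H]1O[C@@H](n2cc(F)c3c(-c4ccccc4)ncnc32)[C@H](O)[C@@H]1O`) gives only a limit, not a number, at > 40000 nM in this series. Compound 2 (`OC[C@H]1O[C@@H](n2cc(F)c3c(-c4ccco4)ncnc32)[C@H](O)[C@@H]1O`) gives 1200 nM and compound 3 (`OC[C@H]1O[C@@H](n2cc(F)c3c(-c4ccsc4)ncnc32)[C@H](O)[C@@H]1O`) gives 4900 nM in the same test, so compound 2 holds the lower of the two actual numbers. Compound 4 (`OC[C@H]1O[C@@H](n2cc(Cl)c3c(-c4ccco4)ncnc32)[C@H](O)[C@@H]1O`) keeps the furan-2-yl group of compound 2 and carries chloro in place of fluoro on an aromatic carbon. The measured steps all concern the other substituent: there is an at least 33-fold lower number from compound 1 to compound 2 (1.52 log units; beyond the scatter) with furan-2-yl in place of phenyl, an at least 8.1-fold lower number from compound 1 to compound 3 (0.91 log units; beyond the scatter) with thiophen-3-yl in place of phenyl, and a 4.1-fold higher number from compound 2 to compound 3 (0.61 log units; beyond the scatter) with thiophen-3-yl in place of furan-2-yl. They show that this assay separates these groups, but none exchanges one halogen for another, so none gives a size for this change. No step beyond the scatter is therefore expected, and no direction is favoured. The expected change is no change at the digits printed from compound 2 to compound 4 (within the scatter) in this estimate. Compound 4 is estimated at 1200 nM with an expected range from 300 nM to 5000 nM in this test.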

Compound 4, half-maximal inhibitory concentration: 21600 nM
Compound 4: middle estimate off by 18-fold (1.26 log units), on the low side, and the stated range ends below it.
By their numbers in this assay, from the lowest: compound 2; then compound 3; then compound 4. At a limit, above all of these: compound 1.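

The halogen on the five-membered aromatic ring, two ring bonds from the ring nitrogen, proves to matter in this assay: there is an 18-fold higher number from compound 2 to compound 4 (1.26 log units; beyond the scatter). Among the compounds shown here, the earlier compounds varied only the other substituent, so this is the first sign that exchanging fluoro for chloro, a swap of one heavy atom for one heavy atom with no hydrogen-bond donor or acceptor involved, also moves the read-out, here towards weaker inhibition. The step is read between two actual numbers, and the only limit in this series belongs to compound 1: the limit of > 40000 nM in this assay, at which 1 of the 4 values shown sits.

On these data alone, the step is known only with furan-2-yl in the other place, so whether it holds with thiophen-3-yl or phenyl stays open. Also open, as far as these compounds go, is how hydrogen, bromo, methyl or an amine would read at this position.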